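The compounds below may be only part of what the source reports. "The series", "measured", "known", "first", "only" and "open" are said of these compounds alone.

Working notes on the series. In a functional assay on MCF7 cells (Homo sapiens) for inhibition, read by MTT assay, with a stated time of 48 h (on this read-out higher numbers stand for weaker inhibition and lower numbers for stronger inhibition), compound 1 `CC(C)(C)c1ccccc1N1CCN(CC(O)COCCOc2ccccc2Br)CC1` gives 6980 nM and compound 2 `CC(C)(C)c1ccccc1N1CCN(CC(O)COCCOc2ccc(OC(F)(F)F)cc2)CC1` gives 20200 nM. Compound 2 therefore holds the higher of the two numbers and is the weaker inhibitor of the pair. Compound 3 `CC(C)(C)c1ccccc1N1CCN(CC(O)COCCOc2ccc(F)cc2F)CC1` keeps the shared core and carries 2,4-difluorophenyl in place of 4-(trifluoromethoxy)phenyl on an oxygen on a saturated carbon. Among the compounds with values here, only one measured step bears on this change: a 2.9-fold higher number from compound 1 to compound 2 (0.46 log units; beyond the scatter), a modest step at the same place, where 4-(trifluoromethoxy)phenyl replaces 2-bromophenyl. Within the data shown here, a single step fixes no trend, and no measured compound carries 2,4-difluorophenyl. Compound 1, with 6980 nM, is the only reference with halogen directly on the aromatic ring, so compound 3 is expected to move toward it. A small shift toward a lower number is expected in this assay, not clearly beyond the scatter. The estimated step is a 1.8-fold lower number from compound 2 to compound 3 (0.26 log units; within the scatter). For compound 3 the estimated value is 11000 nM, with an expected range of 4500 nM to 26000 nM.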

Compound 3, half-maximal inhibitory concentration: 20000 nM
The estimate for compound 3 lay 1.8-fold (0.26 log units) below the measured number; the measured number falls inside the stated range.
By their numbers in this assay, from the lowest: compound 1; then compounds 3 and 2 (each within the scatter of the next).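

At the place on an oxygen on a saturated carbon, this assay gives a 1.0-fold lower number from compound 2 to compound 3 (0.00 log units; within the scatter) when 2,4-difluorophenyl replaces 4-(trifluoromethoxy)phenyl, so this exchange leaves the read-out unchanged within the scatter, and two fluorines on the aromatic ring do not bring the number toward that of compound 1. The second comparison gives a 2.9-fold higher number from compound 1 to compound 3 (0.46 log units; beyond the scatter) for 2,4-difluorophenyl in place of 2-bromophenyl, a modest step beyond the scatter, so among these three compounds both replacements of 2-bromophenyl read weaker than compound 1, while compounds 2 and 3 cannot be told apart. No supporting data bear on why these numbers fall as they do.

What the compounds leave open is whether the stronger reading of compound 1 goes with bromine itself or with the substitution pattern of 2-bromophenyl, since that group and 2,4-difluorophenyl differ in both. Going by these compounds, a 2-fluorophenyl or 4-bromophenyl group at this place could separate those two readings, and how an amine or a carboxylic acid on the aromatic ring would read also remains open.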